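Removing the acetyl from a sugar hydroxyl: the dibromo case

The source may report more compounds than this note shows. Statements on the series, on what has been measured and on what is new or still open speak of the compounds shown alone.

Four compounds share a common core built from a sugar ring, a bicyclic heteroaromatic unit and a coumarin joined through a thioether. Compound 1 `CC(=O)OC[C@H]1O[C@@H](n2c(SCc3cc4ccccc4oc3=O)nc3cncnc32)[C@H](O)[C@@H]1O` carries an acetyl on the sugar's primary oxygen, and compound 3 `O=c1oc2ccccc2cc1CSc1nc2cncnc2n1[C@@H]1O[C@H](CO)[C@@H](O)[C@H]1O` is its counterpart with a free hydroxyl: hydrogen in place of acetyl on an oxygen on a saturated carbon. Compound 2 `CC(=O)OC[C@H]1O[C@@H](n2c(SCc3cc4cc(Br)cc(Br)c4oc3=O)nc3cncnc32)[C@H](O)[C@@H]1O` carries two bromines on the coumarin and keeps the acetyl; compound 4 `O=c1oc2c(Br)cc(Br)cc2cc1CSc1nc2cncnc2n1[C@@H]1O[C@H](CO)[C@@H](O)[C@H]1O` is the dibromo compound with the free hydroxyl, and the change from compound 2 to compound 4 is hydrogen in place of acetyl on an oxygen on a saturated carbon. The difference between the two cores, compound 1 against compound 2, is not broken down here.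

In a functional assay on Huh-5-2 cells (Homo sapiens) for cytotoxicity, read by microscopy (on this read-out lower numbers stand for higher toxicity in this test and higher numbers for lower toxicity in this test), compound 1 gives 8700 nM, compound 2 gives 7000 nM and compound 3 gives 50000 nM. Going by the values given here, the one measured step of this kind, a 5.7-fold higher number from compound 1 to compound 3 (0.76 log units; beyond the scatter), shows the free hydroxyl moving the number upward beyond the scatter. Since the place of the change is the same in both pairs, a step of similar size is expected from compound 2 to compound 4, a 5.7-fold higher number from compound 2 to compound 4 (0.76 log units; beyond the scatter), resting on the step from compound 1 to compound 3. Compound 4 is therefore estimated at 40000 nM in this assay, with a plausible range from 15000 nM to 100000 nM.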

Compound 4, half-maximal cytotoxic concentration: 36000 nM
For compound 4 the middle estimate is 1.1-fold (0.05 log units) above the measured one; the range from low to high includes it.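

In this assay, replacing the acetyl with hydrogen on the dibromo core gives a 5.1-fold higher number from compound 2 to compound 4 (0.71 log units; beyond the scatter), so the free hydroxyl again goes with a higher number, which here means lower toxicity in this test. Set beside the earlier step, the change carries over from one core to the other at much the same size: the same change on two cores in this assay, a 5.7-fold higher number (0.76 log units; beyond the scatter) from compound 1 to compound 3 and a 5.1-fold higher number (0.71 log units; beyond the scatter) from compound 2 to compound 4, 1.1-fold (0.05 log units) apart, within the scatter of two such steps

This supports treating the step as transferable between the core of compound 1 and the core of compound 2, but it rests on just these two pairs, in this one test, and it does not show why the number moves or that the step would hold on any other core.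

The compounds shown have only acetyl or hydrogen on this oxygen, so it remains open how a longer ester such as butyryl, a benzoyl ester or a methyl ether would behave. Going by these compounds, it is also open whether the step would stay the same with a single bromine or with chlorine on the coumarin.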